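A few compounds are considered here, and "the series" means these few. Any claim that something is new, unique, unknown or untested is made for them only; others in the source may bear on it.

Measured so far in an assay on isolated protein for inhibition of S-adenosylmethionine decarboxylase proenzyme (Homo sapiens); a lower number here means a stronger inhibitor, a higher number a weaker inhibitor:
- compound 1 `CNc1nc2c(N)ncnc2n1[C@@H]1O[C@H](CN(C)CCCN)[C@@H](O)[C@H]1O`: 440000 nM
- compound 2 `CN(CCC(=O)NN)C[C@H]1O[C@@H](n2cnc3c(N)ncnc32)[C@H](O)[C@@H]1O`: 1500 nM
- compound 3 `CCc1nc2c(N)ncnc2n1[C@@H]1O[C@H](CN(C)CCCCON)[C@@H](O)[C@H]1O`: 15 nM

Compound 1 stands at the highest number of the three. Its nearest neighbour is compound 2, whose number lies lower by a margin beyond the scatter; compound 3 lies further still, lower by a wide margin. These three differ from one another in more than one place, so no single change can be read off from the measured set.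

Compound 4 `Cc1nc2c(N)ncnc2n1[C@@H]1O[C@H](CN(C)CCCN)[C@@H](O)[C@H]1O` is the next step from compound 1. The change is methyl in place of methylamino on an aromatic carbon. Within the data shown here, no measured pair shows this change alone, so the size of the step has to be estimated. The expectation is that the number falls: compound 3 carries an ethyl at this same place on the core and gives 15 nM, though it also carries a different chain, so only part of that gap can be credited to the core substituent. The step from compound 1 to compound 4 is expected to be a 55-fold lower number from compound 1 to compound 4 (1.74 log units; beyond the scatter), well beyond the scatter. Compound 4 is therefore estimated at 8000 nM, within a range from 800 nM to 80000 nM.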

Compound 4, half-maximal inhibitory concentration: 70000 nM
Compound 4: the middle estimate sits 8.8-fold (0.94 log units) below what was measured; the measured number falls inside the stated range.
By their numbers in this assay, from the lowest: compound 3; then compound 2; then compound 4; then compound 1.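

Among these compounds, with the chain of compound 1 left unchanged, the swap of methylamino for methyl on this aromatic carbon, between two ring nitrogen atoms, gives a 6.3-fold lower number from compound 1 to compound 4 (0.80 log units; beyond the scatter) in this assay, the first step that can be assigned to one place alone. The number falls even though the change removes a hydrogen-bond donor and a hydrogen-bond acceptor, so the donor and acceptor of the methylamino group are not required to reach the number of compound 1, and the smaller methyl is at least as well accepted at this position. Nothing available accounts for the direction or size of this step.

Compound 3 differs from compound 4 in more than one place, so how much of its number belongs to the ethyl and how much to its chain cannot be read from these compounds. Also open, as far as these compounds go, are how a plain hydrogen, an amino group or a propyl group would compare with methyl at this position on the chain of compound 4, and whether the methylamino-to-methyl step keeps its size on a longer chain ending in an aminooxy group.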